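Carboxy in place of ethoxy: working notes on the series

The compounds below may be only part of what the source reports. "The series", "measured", "known", "first", "only" and "open" are said of these compounds alone.

Compound 1 `CC1CC/C(=N\Nc2ccccc2Br)c2ncc(C(=O)O)c(=O)n21`, compound 2 `CCOc1cccc(N/N=C2\CCC(C)n3c2ncc(C(=O)O)c3=O)c1` and compound 3 `Cc1ccccc1N/N=C1\CCC(C)n2c1ncc(C(=O)O)c2=O` share one core and differ only in the group on the six-membered aromatic ring of carbon only. In a functional assay on the whole organism for inhibition, with Rattus norvegicus as the target (on this read-out higher numbers stand for an effect only at larger amounts of compound and lower numbers for an effect already at smaller amounts), compound 1 gives a limit, > 320 umol/kg, and not a number. In this assay compound 2 also gives only a limit, > 1000 umol/kg. In this assay compound 3 gives a limit as well, > 100 umol/kg. All three values are limits, so compound 2 stands at the highest of the three limits but cannot be ordered against compound 1 or compound 3. Going by the values given here, the single one-place step, a step that the two limits leave unreadable from compound 1 to compound 3, cannot be sized either.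

Compound 4 `CC1CC/C(=N\Nc2cccc(C(=O)O)c2)c2ncc(C(=O)O)c(=O)n21` is not yet measured. It differs from compound 2 in one place, (carboxy in place of ethoxy on an aromatic carbon). Among the compounds with values here, no measured step bears on this change: nothing exchanges the ethoxy, and no measured compound carries a carboxy on that ring. With compound 2 itself at a limit, the likeliest outcome is a further limit, and no direction is expected beyond the scatter. Compound 4 is therefore expected to give about 1000 umol/kg in this assay, within 320 umol/kg to 3200 umol/kg. The step of a number no higher from compound 2 to compound 4 (the limit leaves the size open) is expected to stay within the scatter.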

Compound 4, dose for 50% inhibition: > 100 umol/kg
Compound 4 gave a limit, no number; the forecaster's own chance of this, stated with the estimate: 75%; the middle value lies beyond the limit too.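

In this assay compound 4 gives only a limit, > 100 umol/kg, and not a number. Compound 2 also gives only a limit, > 1000 umol/kg, so no step can be read between compound 2 and compound 4. The compounds shown leave open whether any group on the carbon-only aromatic ring yields a number in this assay, and how carboxy and ethoxy compare.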